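Naphthylthiosemicarbazone series: aryl swap and cytotoxicity

The compounds below may be only part of what the source reports. "The series", "measured", "known", "first", "only" and "open" are said of these compounds alone.

Compound 1 `Fc1cc(F)cc(/C=N/NC(=S)Nc2cccc3ccccc23)c1`: > 500 ug/mL
Compound 2 `Fc1ccc(/C=N/NC(=S)Nc2cccc3ccccc23)c(F)c1`: > 500 ug/mL

In an ADME assay on NIH3T3 cells (Mus musculus) for cytotoxicity, read by XTT assay, with a stated time of 24 h (on this read-out higher numbers stand for weaker inhibition and lower numbers for stronger inhibition), compound 1 gives > 500 ug/mL, which is a limit of the assay and not a number. Compound 2 gives > 500 ug/mL, also a limit. The step that the two limits leave unreadable from compound 1 to compound 2 therefore has no readable size, as both values sit at the limit of > 500 ug/mL in this assay, at which 2 of the 2 values shown sit. Compound 3 `Fc1cccc(Cl)c1/C=N/NC(=S)Nc1cccc2ccccc12` differs from compound 1 by 2-chloro-6-fluorophenyl in place of 3,5-difluorophenyl on a carbon with a double bond to nitrogen. Going by the values given here, the only measured step, the one from compound 1 to compound 2, concerns a halogen pattern on the same ring and offers no size to carry over. For compound 3 the expected step is a number no higher from compound 1 to compound 3 (the limit leaves the size open), none beyond the scatter. Compound 3 is estimated at 500 ug/mL, with range 250 ug/mL to 1000 ug/mL.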

Compound 3, half-maximal inhibitory concentration: > 500 ug/mL
Compound 3: no number, only a limit; the forecaster's own chance of this, stated with the estimate: 85%; the middle value lies on the limit itself.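

Compound 3 gives > 500 ug/mL, a limit of the assay and not a number. Its steps from compound 1 and compound 2 therefore cannot be read: the limit of > 500 ug/mL in this assay, at which 3 of the 3 values shown sit.

The compounds shown leave open whether these aryl groups differ at all in this assay.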